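Tetrazole replacing the urea arm: a working estimate

The source may report more compounds than this note shows. Statements on the series, on what has been measured and on what is new or still open speak of the compounds shown alone.

Measured so far:
compound 1, `CCNC(=O)NCc1ccccc1-c1ccc(CN2C(=O)[C@H](NC(=O)C(C)(C)N)CCc3ccccc32)cc1`, 6 nM in a functional assay (Pituitary gland cell) with Rattus norvegicus as the target; on this read-out lower numbers stand for an effect already at smaller amounts and higher numbers for an effect only at larger amounts of compound
compound 2, `CC(C)(N)C(=O)N[C@@H]1CCc2ccccc2N(Cc2ccc(-c3ccccc3CNC(=O)NCc3ccccc3)cc2)C1=O`, 390 nM in this assay

Within the data shown here, compound 2 stands at the higher of the two numbers, with compound 1 as its only neighbour at a much lower number; the step of a 65-fold higher number from compound 1 to compound 2 (1.81 log units; beyond the scatter) is large and beyond the scatter.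

Compound 3, `CC(C)(N)C(=O)N[C@@H]1CCc2ccccc2N(Cc2ccc(-c3ccccc3-c3nn[nH]n3)cc2)C1=O`, is not yet measured. It differs from compound 2 in one place: 2H-tetrazol-5-yl in place of ((benzylcarbamoyl)amino)methyl on an aromatic carbon. Among the measured compounds shown here, the group that leaves is the one whose outer end was changed in the single measured step; that step, a 65-fold higher number from compound 1 to compound 2 (1.81 log units; beyond the scatter), shows that this region of the molecule is sensitive, but it involved a different alteration at a different point, so no measured step maps directly onto the present change. The direction of the new step therefore cannot be read from the data; the sensitivity seen in a 65-fold higher number from compound 1 to compound 2 (1.81 log units; beyond the scatter) only argues that a change of some size, beyond the scatter, is likely.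

With that, compound 3 is expected at 60 nM in this assay, within 6 nM to 600 nM, an estimated step of a 6.5-fold lower number from compound 2 to compound 3 (0.81 log units; beyond the scatter).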

Compound 3, concentration for half-maximal effect: 30 nM
Compound 3: the middle estimate sits 2.0-fold (0.30 log units) above what was measured; the range from low to high includes it.
By their numbers in this assay, from the lowest: compound 1; then compound 3; then compound 2.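

The earlier compounds shown here showed only that the outer end of the urea arm matters; here the whole arm is exchanged, and a 13-fold lower number from compound 2 to compound 3 (1.11 log units; beyond the scatter) in this assay shows that an effect at this level does not require the urea at this place, on an aromatic carbon of a six-membered aromatic ring of carbon only and ortho to a large group. The verdict on the exchange depends on the arm it replaces, since the same 2H-tetrazol-5-yl group gives a 5.0-fold higher number from compound 1 to compound 3 (0.70 log units; beyond the scatter) when set against ((ethylcarbamoyl)amino)methyl, so it improves on the benzyl arm but does not match the ethyl arm. Nothing at hand gives a reason for this order of the three compounds.

The compounds shown leave open whether the gain over the benzyl arm comes from the tetrazole ring itself or simply from the removal of the benzyl end of that arm. A carboxylic acid or a plain aminomethyl group on the same aromatic carbon would help to separate these two readings, and the same holds for a urea arm ending in a propyl chain.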